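Removing the tert-butyl from compound 1

This account rests on a few compounds, and the source may have more. Where it says the series, first, only, none or still open, it means among the compounds named here.

Compound 1 `CC(C)(C)c1cccc2c1CCC2NC(=O)Nc1cccc2[nH]ncc12`: 14 nM
Compound 2 `CC(C)(CO)c1ccc2c(c1)CC[C@H]2NC(=O)Nc1cccc2[nH]ncc12`: 127 nM

In an assay on isolated protein for inhibition of transient receptor potential cation channel subfamily V member 1 (Homo sapiens), read by calcium flux (a lower number here means a stronger inhibitor, a higher number a weaker inhibitor), compound 1 gives the lowest of the two numbers; compound 2 sits at a higher number, and the gap between compound 1 and compound 2 lies beyond the usual scatter. Compound 3 `O=C(Nc1cccc2[nH]ncc12)NC1CCc2ccccc21` has not yet been measured in this assay. It differs from compound 1 in one place: hydrogen in place of tert-butyl on an aromatic carbon. Among the compounds with values here, no step between measured compounds isolates this change, and compound 2 differs from compound 1 in more than one place, so those two values show only that compound 2 is weaker than compound 1. Compound 1, the one carrying the tert-butyl, gives 14 nM in this assay, and the step of a 14-fold higher number from compound 1 to compound 3 (1.15 log units; beyond the scatter) is expected to lead to a clearly higher number, beyond the scatter. For compound 3 the estimate is 200 nM with a range from 40 nM to 1500 nM.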

Compound 3, half-maximal inhibitory concentration: 151 nM
Estimate against measurement, compound 3: 1.3-fold (0.12 log units) above, within the range that was stated.
By their numbers in this assay, from the lowest: compound 1; then compounds 2 and 3 (each within the scatter of the next).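

In this assay, hydrogen in place of tert-butyl on this aromatic carbon gives an 11-fold higher number from compound 1 to compound 3 (1.03 log units; beyond the scatter), a large step beyond the scatter. This single change therefore accounts for a large loss of inhibition on the core of compound 1, which the earlier values could not separate from other structural differences. Nothing on hand explains the size of this step.

The compounds shown leave open whether methyl, isopropyl or trifluoromethyl on the same aromatic carbon would keep the number close to that of compound 1, or whether the full tert-butyl is needed. They also leave open how an amine or a methoxy group would behave at this carbon, as no other single-place change here bears on it.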